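The compounds below may be only part of what the source reports. "The series", "measured", "known", "first", "only" and "open" are said of these compounds alone.

Measured so far in a physicochemical assay for solubility, read by HPLC, using the shake flask method, in phosphate buffer, with a stated time of 20 h, at pH 6.5 (on this read-out lower numbers stand for lower solubility and higher numbers for higher solubility), are two compounds:
- Compound 1 `CN1CCN(CC2CCN(c3nccc4[nH]c(-c5cc(F)cc(C(F)(F)F)c5)nc34)CC2)CC1` gives 165000 nM
- Compound 2 `CN1CCN(CC2CCN(c3nccc4[nH]c(-c5cccc(C(=O)N(C)C)c5)nc34)CC2)CC1` gives 180000 nM

Compound 2 stands level with compound 1, their values lying within the usual scatter of each other. Compound 3 `CN1CCN(CC2CCN(c3nccc4[nH]c(-c5cccc(C(=O)O)c5)nc34)CC2)CC1` differs from compound 2 in one place, with hydroxy in place of dimethylamino on a carbonyl carbon. Within the data shown here, compound 3 is expected to show no shift beyond the scatter in this assay in either direction, going by the only measured step of a 1.1-fold higher number from compound 1 to compound 2 (0.04 log units; within the scatter) in which 3-(dimethylcarbamoyl)phenyl took the place of 3-fluoro-5-(trifluoromethyl)phenyl on an aromatic carbon. Among the measured compounds shown here, no measured compound carries a carboxy group, so this guide is thin. The expected change is a 1.1-fold lower number from compound 2 to compound 3 (0.02 log units; within the scatter) by this estimate. Compound 3 is estimated at 170000 nM within an expected span of 80000 nM to 320000 nM for this measurement.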

Compound 3, solubility: 195000 nM
Compound 3: middle estimate off by 1.1-fold (0.06 log units), on the low side; low and high end bracket the measured number.
By their numbers in this assay, from the lowest: compounds 1, 2 and 3 (each within the scatter of the next).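

In this assay hydroxy in place of dimethylamino on a carbonyl carbon gives a 1.1-fold higher number from compound 2 to compound 3 (0.03 log units; within the scatter) and so leaves the read-out level. 3-carboxyphenyl in place of 3-fluoro-5-(trifluoromethyl)phenyl gives a 1.2-fold higher number from compound 1 to compound 3 (0.07 log units; within the scatter), so all three aryl groups shown read alike. Nothing available here accounts for these level values.

On these data alone, whether a sulfonamide or a longer chain ending in an amine, in place of the carboxy group, would read the same stays open. So does whether any change to the shared core would move the number.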